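Changing the Ring Substituent: an Expectation for Compound 4

The compounds below may be only part of what the source reports. "The series", "measured", "known", "first", "only" and "open" are said of these compounds alone.

Compound 1 `CC1=C(/C=C/C(=O)/C=C/c2ccc(Cl)cc2)C(C)(C)CCC1` gives 9500 nM in a functional assay on PC-3 cells (Homo sapiens) for cytotoxicity, read by sulforhodamine B assay, with a stated time of 48 h; on this read-out higher numbers stand for weaker inhibition and lower numbers for stronger inhibition. Compound 2 `CC1=C(/C=C/C(=O)/C=C/c2ccc(Br)cc2)C(C)(C)CCC1` gives 18900 nM. Compound 3 `CC1=C(/C=C/C(=O)/C=C/c2ccc(C#N)cc2)C(C)(C)CCC1` gives 11900 nM.

Compound 3 stands second highest of the three numbers: the step of a 1.3-fold higher number from compound 1 to compound 3 (0.10 log units; within the scatter) and the step of a 1.6-fold lower number from compound 2 to compound 3 (0.20 log units; within the scatter) both stay within the scatter. Compound 4 `CC1=C(/C=C/C(=O)/C=C/c2ccc(C)cc2)C(C)(C)CCC1` differs from compound 3 by methyl in place of cyano on an aromatic carbon. Among the compounds with values here, no measured step involves a methyl, so only the three swaps among chloro, bromo and cyano bear on this change: a 2.0-fold higher number from compound 1 to compound 2 (0.30 log units; within the scatter), a 1.3-fold higher number from compound 1 to compound 3 (0.10 log units; within the scatter) and a 1.6-fold lower number from compound 2 to compound 3 (0.20 log units; within the scatter), all within the scatter. The expected step is therefore a 1.0-fold higher number from compound 3 to compound 4 (0.00 log units; within the scatter), with no change beyond the scatter. Compound 4 is estimated at 12000 nM, within a range from 5000 nM to 30000 nM.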

Compound 4, half-maximal inhibitory concentration: 21500 nM
Estimate against measurement, compound 4: 1.8-fold (0.25 log units) below; the measured number falls inside the stated range.
By their numbers in this assay, from the lowest: compounds 1, 3, 2 and 4 (each within the scatter of the next, the first and the last beyond it).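

Methyl in place of chloro gives the only step at this ring position that reaches beyond the scatter, and it is a modest one (a 2.3-fold higher number from compound 1 to compound 4 (0.35 log units; beyond the scatter)). Methyl in place of the other two groups stays within the scatter (a 1.8-fold higher number from compound 3 to compound 4 (0.26 log units; within the scatter); a 1.1-fold higher number from compound 2 to compound 4 (0.06 log units; within the scatter)), so the four groups span a narrow band of values. Nothing measured here explains why methyl separates from chloro alone.

From the compounds shown here alone, whether an amine or a carboxylic acid at this position would move the number further remains open. So does whether a longer chain there would fall within the same band.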